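A few compounds are considered here, and "the series" means these few. Any claim that something is new, unique, unknown or untested is made for them only; others in the source may bear on it.

Three compounds have been examined in an ADME assay on HepG2 2.2.15 cells (Homo sapiens) for cytotoxicity; on this read-out lower numbers stand for higher toxicity in this test and higher numbers for lower toxicity in this test. Compound 1 `O=C(Nc1ncc(Cc2ccc(Br)cc2)s1)c1ccc2ccccc2c1` carries an amide on the shared core, while compound 2 `COC(=O)CCCCNc1ncc(C(Oc2ccc3cc(Br)ccc3c2)c2ccc(Cl)cc2)s1` and compound 3 `COc1ccc(C(=O)Nc2ncc(C(Sc3ccc4ccccc4c3)c3ccc(Cl)cc3)s2)cc1` carry a naphthalene linked through oxygen or sulfur beside a 4-chlorophenyl group. In this assay compound 1 gives > 50000 nM, which is a limit of the assay rather than a number. Compound 2 is recorded in this assay as "not toxic" (no number reported), an entry without any single number. Compound 3 is likewise recorded as "not toxic" (no number reported). So compound 2 stands among compounds that all show low toxicity here: no single number is given for it, one further value is a limit, namely (the limit of > 50000 nM in this assay, at which 1 of the 3 values shown sits), and one further entry carries no number at all.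

Compound 4 `O=S(=O)(Nc1ncc(C(Oc2ccc3cc(Br)ccc3c2)c2ccc(Cl)cc2)s1)c1ccccc1` has not yet been tested. It differs from compound 2 at one place: phenylsulfonyl in place of 4-(methoxycarbonyl)butyl on a nitrogen on an aromatic ring. No measured pair in this set shows a step of this kind, so there is nothing to point to as a cause. Going by the values given here, since every value so far lies at or beyond the upper edge of what this assay reports, the step from compound 2 to compound 4 is expected to be none beyond the scatter, with compound 4 staying in the low-toxicity range. Compound 4 is therefore estimated at 50000 nM, within a range from 20000 nM to 100000 nM.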

Compound 4, half-maximal cytotoxic concentration: > 50000 nM
Compound 4 ended at the assay's limit (the forecaster's own chance of this, stated with the estimate: 70%); the middle value sits exactly at the limit.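

In this assay compound 4 gives > 50000 nM, which is a limit of the assay and not a number. Going by these compounds alone, compound 2 has no number either, and no step between compound 2 and compound 4 can be read. The compounds shown leave open whether phenylsulfonyl and 4-(methoxycarbonyl)butyl differ in cytotoxicity at all, and which change, if any, would bring measurable toxicity.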